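The source may hold more compounds than are shown below. What is called first, only, known or untested is meant among the compounds shown, and "the series" means these compounds.

Measured in an ADME assay for permeability, using PAMPA, with a stated time of 30 min, at pH 7.4; a lower number here means that the compound crosses the layer more slowly, a higher number that the compound crosses the layer faster:
compound 1 `COc1ccccc1Oc1ccc2c(NCCCNCc3ccco3)ccnc2c1` gives 317 10^-6 cm/s
compound 2 `c1ccc(Oc2ccc3c(NCCCNCc4ccco4)ccnc3c2)cc1` gives 317 10^-6 cm/s
compound 3 `CC(C)CCc1ccc2c(NCCCNCc3ccco3)ccnc2c1` gives 23 10^-6 cm/s

Compound 3 stands lowest of the three; compound 1 and compound 2 lie within the scatter of each other, both far above it. Compound 4 `COc1ccc(-c2ccc3c(NCCCNCc4ccco4)ccnc3c2)cc1` is not yet measured. The change from compound 3 to compound 4 is 4-methoxyphenyl in place of isopentyl on an aromatic carbon. Within the data shown here, the steps that bear on it run the other way, a 14-fold lower number from compound 1 to compound 3 (1.14 log units; beyond the scatter) and a 14-fold lower number from compound 2 to compound 3 (1.14 log units; beyond the scatter), each an aryl ether giving way to isopentyl. Returning an aromatic ring to that carbon, now as 4-methoxyphenyl instead of 2-methoxyphenoxy or phenoxy, is expected to raise this assay by about an 8.7-fold higher number from compound 3 to compound 4 (0.94 log units; beyond the scatter); no directly attached aryl group has been measured, so the range is wide. Compound 4 is expected to give about 200 10^-6 cm/s, between 60 10^-6 cm/s and 500 10^-6 cm/s.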

Compound 4, apparent permeability: 237 10^-6 cm/s
Estimate against measurement, compound 4: 1.2-fold (0.07 log units) below, and the stated range covers the measured number.
By their numbers in this assay, from the lowest: compound 3; then compounds 4, 1 and 2 (each within the scatter of the next).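

In this assay, a directly attached aryl group at this aromatic carbon behaves like the aryl ethers: swapping in 4-methoxyphenyl gives a 1.3-fold lower number from compound 2 to compound 4 (0.13 log units; within the scatter) and a 1.3-fold lower number from compound 1 to compound 4 (0.13 log units; within the scatter), whereas replacing isopentyl gives a 10-fold higher number from compound 3 to compound 4 (1.01 log units; beyond the scatter). Among these compounds, the ether oxygen is therefore not needed for the higher numbers, and compound 3 alone stands apart. No evidence on the reason for this pattern is at hand. Still open, going by these compounds, is whether a cyclohexyl ring, a longer chain or an aryl group bearing an amine at this carbon would stay with the aryl compounds or fall towards compound 3.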